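Furan for Benzofuran on Two Related Cores

The source may report more compounds than this note shows. Statements on the series, on what has been measured and on what is new or still open speak of the compounds shown alone.

Four compounds share a core and differ in the aromatic group attached to it and in the core itself. Compound 1 `O=c1[nH]cnc2c1c(-c1ccco1)cn2[C@@H]1O[C@H](CO)[C@@H](O)[C@H]1O` and compound 2 `O=c1[nH]cnc2c1c(-c1cc3ccccc3o1)cn2[C@@H]1O[C@H](CO)[C@@H](O)[C@H]1O` carry one core; compound 3 `Nc1nc(N)c2c(-c3cc4ccccc4o3)cn([C@@H]3O[C@H](CO)[C@@H](O)[C@H]3O)c2n1` and compound 4 `Nc1nc(N)c2c(-c3ccco3)cn([C@@H]3O[C@H](CO)[C@@H](O)[C@H]3O)c2n1` carry another, and how the two cores differ is not broken down here. In a functional assay on HCT-116 cells (Homo sapiens), read by MTT assay, with a stated time of 72 h (on this read-out higher numbers stand for weaker inhibition and lower numbers for stronger inhibition), compound 1 gives 18300 nM. Compound 2 reaches only the limit of this assay, > 20000 nM. Compound 3 likewise reaches only the limit, > 20000 nM. The change furan-2-yl in place of 1-benzofuran-2-yl on an aromatic carbon gives an at least 1.0-fold lower number from compound 2 to compound 1 (0.03 log units; that floor lies within the scatter), a step bounded by the limit of > 20000 nM in this assay, at which 2 of the 3 values shown sit. The same change, (furan-2-yl in place of 1-benzofuran-2-yl on an aromatic carbon), leads from compound 3 to compound 4. Since the earlier step of an at least 1.0-fold lower number from compound 2 to compound 1 (0.03 log units; that floor lies within the scatter) was small, the expected step here is a number no higher from compound 3 to compound 4 (the limit leaves the size open). Compound 4 is therefore estimated at 20000 nM, with a likely range from 7000 nM to 50000 nM.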

Compound 4, half-maximal inhibitory concentration: > 20000 nM
Compound 4: only a limit was reported; the forecaster's own chance of this, stated with the estimate: 60%; the middle value lies on the limit itself.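

No step can be read from compound 3 to compound 4, because each gives only a limit and not a number: the limit of > 20000 nM in this assay, at which 3 of the 4 values shown sit. The compounds shown leave open whether furan-2-yl in place of 1-benzofuran-2-yl changes the number on this core at all.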